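One added methyl on a small branched chain

The source may hold more compounds than are shown below. What is called first, only, known or untested is meant among the compounds shown, and "the series" means these compounds.

Three small branched compounds have numbers in a functional assay on the whole organism (strain Sprague-Dawley albino) with Rattus norvegicus as the target, with a stated time of 0.5 h; on this read-out higher numbers stand for an effect only at larger amounts of compound and lower numbers for an effect already at smaller amounts: compound 1 `CCC(C)C(CC)COC(N)=O` gives 96 mg/kg, compound 2 `CCCC(COC(N)=O)C(C)C` gives 107 mg/kg, and compound 3 `CC(C)C(COC(N)=O)C(C)C` gives 94 mg/kg. All three lie within the scatter of one another, so compound 3 stands level with the other two.

Compound 4 `CCC(C)C(COC(N)=O)C(C)C` differs from compound 3 by a single change, methyl in place of hydrogen on a saturated chain carbon, four bonds along the chain from an oxygen next to a carbonyl group. This turns isopropyl into sec-butyl.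

Going by the values given here, the one measured step that bears on this is a 1.1-fold lower number from compound 2 to compound 3 (0.06 log units; within the scatter), with isopropyl in place of propyl, and it lies within the scatter. Compound 1 already carries a sec-butyl group and gives 96 mg/kg. No step beyond the scatter is therefore expected in this assay, and the estimated step is a 1.0-fold lower number from compound 3 to compound 4 (0.02 log units; within the scatter). For compound 4 the expected value is 90 mg/kg, with an estimated range of 55 mg/kg to 145 mg/kg.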

Compound 4, dose for half-maximal effect: 114 mg/kg
Compound 4: the middle estimate sits 1.3-fold (0.10 log units) below what was measured; the range from low to high includes it.
By their numbers in this assay, from the lowest: compounds 3, 1, 2 and 4 (each within the scatter of the next).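

In this assay the methyl added four bonds along the chain from an oxygen next to a carbonyl group, which turns isopropyl into sec-butyl, gives a 1.2-fold higher number from compound 3 to compound 4 (0.08 log units; within the scatter) and so leaves no readable effect at this position. The comparisons with the other two compounds read the same way, with a 1.1-fold higher number from compound 2 to compound 4 (0.03 log units; within the scatter) and a 1.2-fold higher number from compound 1 to compound 4 (0.07 log units; within the scatter) both showing that compound 4 stands level with them. So a sec-butyl group is accepted here as readily as isopropyl in this whole-animal test, and no measurement shown explains why the read-out stays flat.

Going by these compounds, all the groups compared here are small saturated carbon branches, so it remains open whether anything at this position can move the number. A much longer chain, an amine or a carboxylic acid in place of the sec-butyl group would test that.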